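Taking the chloro group off compound 2

The source may hold more compounds than are shown below. What is called first, only, known or untested is meant among the compounds shown, and "the series" means these compounds.

Of the compounds shown here, three sharing one core have been tested in a functional assay on cells (T-cell, Mus musculus, strain BALB/c) for inhibition, read by MTT assay, with stated times of 24 h and 72 h; on this read-out higher numbers stand for weaker inhibition and lower numbers for stronger inhibition. Compound 1 `COc1cc(-c2nnc(SCc3cccc([N+](=O)[O-])c3)o2)ccc1O` gives 16000 nM. Compound 2 `COc1cc(-c2nnc(SCc3ccc(Cl)cc3)o2)ccc1O` gives 11100 nM. Compound 3 `COc1cc(-c2nnc(SCc3c(F)cccc3F)o2)ccc1O` gives 10100 nM. Compound 2 thus holds the second highest of the three numbers, with compound 3 nearest to it and compound 1 furthest from it, and both of those gaps fall within the usual scatter of repeated measurements.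

Among the measured compounds shown here, the only single-point change measured so far is the one from compound 2 to compound 3, where a 2,6-difluorophenyl replaces a 4-chlorophenyl on a saturated chain carbon bound to a sulfur, and it gives a 1.1-fold lower number from compound 2 to compound 3 (0.04 log units; within the scatter). Swapping one substituted aromatic ring for another at this position therefore left the number essentially where it was.

Compound 4 `COc1cc(-c2nnc(SCc3ccccc3)o2)ccc1O`, not yet measured, differs from compound 2 in one place: hydrogen in place of chloro on an aromatic carbon. For the measured compounds named here, no measured step removes a group from this ring outright, but the one step that does alter the ring, from compound 2 to compound 3, stayed within the scatter. The same is expected here, with a 1.1-fold higher number from compound 2 to compound 4 (0.03 log units; within the scatter) in this assay amounting to nothing beyond the scatter. Compound 4 is accordingly estimated at 12000 nM, within a range from 6000 nM to 25000 nM.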

Compound 4, half-maximal inhibitory concentration: 1250 nM
Compound 4: the middle estimate sits 9.6-fold (0.98 log units) above what was measured; the measured number lies below the stated range.
By their numbers in this assay, from the lowest: compound 4; then compounds 3, 2 and 1 (each within the scatter of the next).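

In this assay, compound 4, whose phenyl ring carries no substituent, separates clearly from all three compounds with a substituted ring (an 8.9-fold lower number from compound 2 to compound 4 (0.95 log units; beyond the scatter); an 8.1-fold lower number from compound 3 to compound 4 (0.91 log units; beyond the scatter); a 13-fold lower number from compound 1 to compound 4 (1.11 log units; beyond the scatter)). The earlier step between two substituted rings suggested that this position made little difference, but the ring does matter: the 4-chlorophenyl, 2,6-difluorophenyl and nitro-bearing compounds sit together within the scatter, while compound 4 stands apart as the strongest of the four. The data offer nothing that accounts for this separation, so the reason for it remains unknown.

The compounds shown cannot tell whether any group on an aromatic carbon para to a large group would raise the number, since only chloro and nitro stand at ring positions of that kind among the single substituents here, and a methyl, a methoxy or an amine there could behave differently. On these data alone, it also remains open whether the phenyl ring itself is needed, or whether a longer chain or a pyridine ring could take its place on the saturated chain carbon bound to the sulfur.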